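The source may hold more compounds than are shown below. What is called first, only, known or untested is meant among the compounds shown, and "the series" means these compounds.

Measured so far in a functional assay on HL-60 cells (Homo sapiens) for antiproliferative activity, read by MTT assay, with a stated time of 48 h; a lower number here means a stronger inhibitor, a higher number a weaker inhibitor:
- Compound 1 `CN(C)CCn1c(N)c(-c2nc3ccccc3[nH]2)c2nc(C#N)c(C#N)nc21`: 2220 nM
- Compound 2 `CN1CCN(CCn2c(N)c(-c3nc4ccccc4[nH]3)c3nc(C#N)c(C#N)nc32)CC1`: 4300 nM
- Compound 3 `CCCCn1c(N)c(-c2nc3ccccc3[nH]2)c2nc(C#N)c(C#N)nc21`: > 50000 nM (a limit of the assay, not a number)

Compound 2 cannot be told apart from compound 1 on these numbers, as a 1.9-fold higher number from compound 1 to compound 2 (0.29 log units; within the scatter) lies within the scatter. The next structure, compound 4 `N#Cc1nc2c(-c3nc4ccccc4[nH]3)c(N)n(CCCN3CCCCC3)c2nc1C#N`, has (piperidin-1-yl)methyl in place of 4-methylpiperazin-1-yl on a saturated chain carbon, two bonds along the chain from an aromatic nitrogen. Cut one bond further out, this reads 2-(4-methylpiperazin-1-yl)ethyl to 3-(piperidin-1-yl)propyl.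

Two kinds of measured step bear on this change. Replacing dimethylamino with 4-methylpiperazin-1-yl gave only the small step of a 1.9-fold higher number from compound 1 to compound 2 (0.29 log units; within the scatter). Replacing either group with ethyl gave the large steps of an at least 22-fold higher number from compound 1 to compound 3 (1.35 log units; beyond the scatter) and an at least 11-fold higher number from compound 2 to compound 3 (1.06 log units; beyond the scatter), whose sizes rest on a limit: the limit of > 50000 nM in this assay, at which 1 of the 3 values shown sits. Compound 4 keeps a ring containing nitrogen, so it resembles compound 1 and compound 2 more than compound 3. For the measured compounds named here, no measured compound carries 3-(piperidin-1-yl)propyl, so the direction stays open, and no step beyond the scatter is expected in this assay. The expected step is a 1.2-fold lower number from compound 2 to compound 4 (0.09 log units; within the scatter). The estimated value for compound 4 is 3500 nM, within an expected range of 1200 nM to 10000 nM.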

Compound 4, half-maximal inhibitory concentration: 1680 nM
Beside the measured number, compound 4's estimate is 2.1-fold (0.32 log units) above it; the measured number falls inside the stated range.
By their numbers in this assay, from the lowest: compounds 4, 1 and 2 (each within the scatter of the next, the first and the last beyond it). At a limit, above all of these: compound 3.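

In this assay, for the compounds shown here, a 2.6-fold lower number from compound 2 to compound 4 (0.41 log units; beyond the scatter) is the first step beyond the scatter among the compounds whose side chain ends in an amine, although it is only a modest one, while a 1.3-fold lower number from compound 1 to compound 4 (0.12 log units; within the scatter) stays within the scatter, so compound 4 cannot be told apart from compound 1. The amine end and chain length can therefore change without a large shift, though not every such change is neutral. Replacing methyl with piperidin-1-yl at the chain end gives an at least 29-fold lower number from compound 3 to compound 4 (1.47 log units; beyond the scatter), so a third amine-bearing compound now separates clearly from the compound with the plain butyl chain. Compound 3 stands at a limit of the assay, not a number, so the size of that step is only a bound: the limit of > 50000 nM in this assay, at which 1 of the 4 values shown sits.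

Compound 4 differs from compound 2 in both its ring and its chain length, so the two contributions remain unseparated; a 2-(piperidin-1-yl)ethyl chain or a 3-(dimethylamino)propyl chain would pull them apart. Also open, going by these compounds, is how a morpholine ring, a primary amine or a still longer chain would read at this position.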